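Swapping Nitro for Oxazole: Expected Solubility of Compound 4

The source may hold more compounds than are shown below. What is called first, only, known or untested is meant among the compounds shown, and "the series" means these compounds.

Compound 1 `NC(=O)c1ccc(-c2cc(-c3ccc([N+](=O)[O-])cc3)nc(-c3ccco3)c2)cc1` was measured in a physicochemical assay for solubility, at pH 6 (a higher number here means a more soluble compound, a lower number a less soluble compound), and gives 8000 nM, which is the lowest number among the three measured compounds. Compound 3 `Cn1nncc1-c1cc(-c2ccc(C(N)=O)cc2)cc(-c2ccc(C#N)cc2)n1` gives 32000 nM, and compound 2 `N#Cc1ccc(-c2cc(-c3ccc(C(N)=O)cc3)cc(-c3cnco3)n2)cc1` gives 250000 nM, the highest of the three. Compound 1 thus sits clearly below both of them, beyond the scatter in each case.

The compound now in question is compound 4 `NC(=O)c1ccc(-c2cc(-c3ccc(-c4cnco4)cc3)nc(-c3ccco3)c2)cc1`. Its structure departs from compound 1 in one place: 1,3-oxazol-5-yl in place of nitro on an aromatic carbon.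

Going by the values given here, no measured pair repeats this exact exchange. Among the compounds with values here, the only step recorded between measured compounds is a 7.8-fold lower number from compound 2 to compound 3 (0.89 log units; beyond the scatter), which concerns a different five-membered ring at a different position and so says little directly about replacing a nitro group. What can be noted is that compound 2, which carries a 1,3-oxazol-5-yl group, shows the highest number, while compound 1, carrying the nitro group, shows the lowest. On that weak basis a rise is expected from compound 1 to compound 4, of about a 2.5-fold higher number from compound 1 to compound 4 (0.40 log units; beyond the scatter). The estimate for compound 4 in this assay is therefore 20000 nM, with a plausible range from 5000 nM to 80000 nM.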

Compound 4, solubility: 15000 nM
Beside the measured number, compound 4's estimate is 1.3-fold (0.12 log units) above it; low and high end bracket the measured number.
By their numbers in this assay, from the lowest: compounds 1 and 4 (each within the scatter of the next); then compound 3; then compound 2.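

In this assay, putting 1,3-oxazol-5-yl in place of nitro on this aromatic carbon gives a 1.9-fold higher number from compound 1 to compound 4 (0.27 log units; within the scatter), so compound 1 and compound 4 cannot be told apart in this measurement. Going by these compounds alone, this is the first direct reading at this position, as the only earlier step concerned a different place on a different compound, and it shows that a small group with no ring and a five-membered aromatic ring with more heavy atoms can occupy this site without a separation beyond the usual scatter. No measurement is available that explains this outcome.

Only these two groups are shown at this position, so it remains open whether an amine, a carboxylic acid or a longer chain on the same aromatic carbon would give a similar number or a clearly different one. Going by these compounds, it also remains open whether the same exchange would give a similar result on another core, such as the core of compound 2.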